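Swapping the Outer Ring Substituent from Trifluoromethyl to Nitro

A few compounds are considered here, and "the series" means these few. Any claim that something is new, unique, unknown or untested is made for them only; others in the source may bear on it.

Measured compounds:
compound 1, `COc1ccc(CO/N=C/c2c(C)nn(C)c2Oc2ccc(Cl)cc2)cc1`: 13.9%
compound 2, `Cc1ccc(CO/N=C/c2c(C)nn(C)c2Oc2ccc(Cl)cc2)cc1`: 31.3%
compound 3, `Cc1nn(C)c(Oc2ccc(Cl)cc2)c1/C=N/OCc1ccc(C(F)(F)F)cc1`: 20.6%

All three share one core and differ only in a single group on the outer benzene ring. In a functional assay on HepG2 cells (Homo sapiens) for antiproliferative activity, tested at 1 uM (a higher number here means more inhibition at the concentration tested (going by the name of the read-out), a lower number less inhibition), compound 3 gives 20.6%, the second highest of the three numbers. Against compound 1 the difference is small, a number 6.7 percentage points higher from compound 1 to compound 3 (within the scatter), whereas compound 2 sits higher, a number 10.7 percentage points lower from compound 2 to compound 3 (beyond the scatter).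

Compound 4, `Cc1nn(C)c(Oc2ccc(Cl)cc2)c1/C=N/OCc1ccc([N+](=O)[O-])cc1`, carries the change (nitro in place of trifluoromethyl on an aromatic carbon). Within the data shown here, no measured step exchanges exactly these two groups, so the three steps at this same position are the only guide: a number 17.4 percentage points higher from compound 1 to compound 2 (beyond the scatter), a number 6.7 percentage points higher from compound 1 to compound 3 (within the scatter) and a number 10.7 percentage points lower from compound 2 to compound 3 (beyond the scatter), all modest. A similarly modest step, in either direction, is therefore expected for compound 4, and the estimate is a number 1.4 percentage points higher from compound 3 to compound 4 (within the scatter). For compound 4 a value of 22% is estimated, with an expected range from 9% to 36%.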

Compound 4, a percentage reported as inhibition, at one concentration (the size of the read-out at that concentration, not a potency): 18.4%
Estimate against measurement, compound 4: 3.6 percentage points above; measured number inside the range.
By their numbers in this assay, from the lowest: compounds 1, 4 and 3 (each within the scatter of the next); then compound 2.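

In this assay, putting nitro in place of trifluoromethyl on the outer ring leaves the result unresolved, with a number 2.2 percentage points lower from compound 3 to compound 4 (within the scatter) as the step for this exchange. The nitro compound is also not separated from the methoxy compound, with a number 4.5 percentage points higher from compound 1 to compound 4 (within the scatter) as that step, so the nitro, trifluoromethyl and methoxy compounds now form one group whose numbers cannot be ordered. Methyl alone stands apart, with a number 12.9 percentage points lower from compound 2 to compound 4 (beyond the scatter) as the newest step, and compound 2 now has steps beyond the scatter to all three other compounds.

Going by these compounds, whether this separation is particular to methyl, or would also appear with an ethyl group, a chlorine atom or an amine at the same place on the ring, remains open. Nothing measured on these compounds accounts for the numbers.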